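Compound 3: A Methyl Added to Compound 2

The source may hold more compounds than are shown below. What is called first, only, known or untested is meant among the compounds shown, and "the series" means these compounds.

Measured so far:
Compound 1, `O=S1(=O)N=C(NCC2CCCCC2)Nc2ncccc21`: in a functional assay (ileum) for inhibition, with Cavia porcellus as the target (a higher number here means that more compound is needed for the effect, a lower number that less compound is needed), compound 1 gives 145 uM.
Compound 2, `O=S1(=O)N=C(NCc2ccccc2)Nc2ncccc21`: in this assay compound 2 gives > 300 uM, which is a limit of the assay and not a number.

Compound 2 thus stands at the edge of what this assay can report (the limit of > 300 uM in this assay, at which 1 of the 2 values shown sits). Going by the values given here, the only measured step, an at least 2.0-fold higher number from compound 1 to compound 2 (0.31 log units; beyond the scatter), is at least modest and runs toward a higher number. Compound 3, `C[C@@H](NC1=NS(=O)(=O)c2cccnc2N1)c1ccccc1`, differs from compound 2 by methyl in place of hydrogen on a saturated chain carbon bound to an amine nitrogen and an aromatic carbon. Among the compounds with values here, no measured step alters that carbon in this way, so the change from compound 1 to compound 2 does not bear on it directly; it shows only that compound 2 already sits where numbers stop. With nothing to point a direction, compound 3 is expected to move little from compound 2, a step that the limit leaves unreadable from compound 2 to compound 3. Compound 3 is therefore estimated at 400 uM, with a range from 150 uM to 1200 uM, and most probably again reported only as a limit.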

Compound 3, concentration for half-maximal effect: > 300 uM
Compound 3 was reported as a limit; the forecaster's own chance of this, stated with the estimate: 70%; the middle value does not contradict the limit.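

Going by these compounds alone, compound 2 and compound 3 both stand at a limit in this assay and not at a number, so no step between them can be read. The compounds shown leave open whether methyl in place of hydrogen on that carbon changes the number at all, and in which direction.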